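The compounds below may be only part of what the source reports. "The series", "measured", "known", "first", "only" and "open" are said of these compounds alone.

Measured compounds:
- Compound 1, `CCSC(=S)SCC(=O)c1ccc(C(=O)N[C@@H](C)c2ccccc2)s1`, gives 135 nM in an assay on HEK293 cells for inhibition of protein deacetylase HDAC6 (Homo sapiens); on this read-out lower numbers stand for stronger inhibition and higher numbers for weaker inhibition.
- Compound 2, `CCSC(=S)SCC(=O)c1ccc(-c2ccc(N)cn2)s1`, gives 43 nM in this assay.

Of these two numbers, compound 1 stands at the higher one, meaning the weaker inhibition; compound 2 sits lower by a gap that is beyond the usual scatter. Compound 3, `CCSC(=S)SCC(=O)c1ccc(C(=O)NCc2ccccc2)s1`, has not yet been measured. It differs from compound 1 in one place: hydrogen in place of methyl on a saturated chain carbon bound to an amide-type nitrogen and an aromatic carbon. Within the data shown here, no measured pair shows a step of just this kind, so its size has to be guessed rather than read off. The change removes only a small group from a saturated chain carbon, and I expect a modest shift at most, most likely one that stays within the scatter, with a slight lean toward a weaker number. For compound 3 the value in this assay is estimated at 160 nM, with a range from 60 nM to 420 nM. The step this estimate implies, a 1.2-fold higher number from compound 1 to compound 3 (0.07 log units; within the scatter), is expected to be no larger than the scatter of the assay.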

Compound 3, half-maximal inhibitory concentration: 44 nM
Beside the measured number, compound 3's estimate is 3.6-fold (0.56 log units) above it; measured number below the stated range.
By their numbers in this assay, from the lowest: compounds 2 and 3 (each within the scatter of the next); then compound 1.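

In this assay, the methyl on the saturated chain carbon proves to matter: exchanging it for hydrogen, which turns 1-phenylethyl into benzyl, gives a clear change (a 3.1-fold lower number from compound 1 to compound 3 (0.49 log units; beyond the scatter)). This position therefore responds to the loss of a single carbon, and in this pair the smaller group goes with the stronger inhibition. The data shown offer no explanation for this step.

As far as these compounds go, it remains open whether an ethyl or a hydroxyl group on this same carbon would give a number closer to that of compound 1 or to that of compound 3, and whether the mirror-image form of compound 1 would behave like compound 1. From the compounds shown here alone, the step also rests on a single pair, so whether it carries over to other cores is unknown.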